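The compounds below may be only part of what the source reports. "The series", "measured", "known", "first", "only" and "open" are said of these compounds alone.

Measured compounds:
compound 1 `CCN(Cc1ccccc1)C(=O)c1nc(-c2ccccc2Cl)c2ccccc2n1` — 0.235 nM
compound 2 `CCN(Cc1ccc(C)cc1)C(=O)c1nc(-c2ccccc2)c2ccccc2n1` — 2.57 nM
compound 3 `CCN(Cc1ccc(C)cc1)C(=O)c1nc(-c2ccccc2F)c2ccccc2n1` — 0.6 nM

In an assay on cell membranes from kidney for displacement of a labelled ligand from Translocator protein (Rattus norvegicus) (a higher number here means a weaker inhibitor, a lower number a stronger inhibitor), compound 3 gives the second-highest of the three numbers. Compound 1 gives a lower number, and compound 2 a higher one, so compound 3 sits between them. Among the measured compounds shown here, the single counted step among the measured compounds is the one in which fluoro replaces hydrogen on an aromatic carbon: a 4.3-fold lower number from compound 2 to compound 3 (0.63 log units; beyond the scatter). Compound 4 `CCN(Cc1ccc(C)cc1)C(=O)c1nc(-c2ccccc2Cl)c2ccccc2n1` is not yet measured. It differs from compound 3 in one place only: chloro in place of fluoro on an aromatic carbon.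

That step bears on the earlier one. Going from hydrogen to fluoro at this position already gave a modest drop in the number, and compound 1, which carries chloro at the same place on a benzyl rather than a methylbenzyl side chain, gives the lowest value among the three. Compound 4 is therefore expected to move in the same direction, with a 2.0-fold lower number from compound 3 to compound 4 (0.30 log units; within the scatter) as the estimated step. Compound 4 is estimated at 0.3 nM in this assay, within a range of 0.12 nM to 0.8 nM.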

Compound 4, inhibition constant: 0.489 nM
Compound 4: the middle estimate sits 1.6-fold (0.21 log units) below what was measured; measured number inside the range.
By their numbers in this assay, from the lowest: compound 1; then compounds 4 and 3 (each within the scatter of the next); then compound 2.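

In this assay, the 2-fluorophenyl to 2-chlorophenyl change leaves the two halogens indistinguishable, with a 1.2-fold lower number from compound 3 to compound 4 (0.09 log units; within the scatter). Chloro in place of hydrogen at this place gives a 5.3-fold lower number from compound 2 to compound 4 (0.72 log units; beyond the scatter), so the drop seen with fluoro is not unique to fluoro but also appears with a second halogen. Among the compounds shown here, with chloro held fixed, the new compound also gives the first reading of the other side of the molecule: adding a methyl group to the benzyl side chain gives a 2.1-fold higher number from compound 1 to compound 4 (0.32 log units; beyond the scatter).

As far as these compounds go, whether bromo, methoxy or trifluoromethyl at this place would keep the number where the two halogens put it remains open. Nothing available here accounts for any of these steps.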